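Fluoroaryl change from compound 2 to compound 3

The source may report more compounds than this note shows. Statements on the series, on what has been measured and on what is new or still open speak of the compounds shown alone.

Compound 1 `COc1ccc(/C=C/C(=O)c2ccccc2-c2ccc(F)cc2)cc1OC` gives 570 nM
Compound 2 `COc1ccc(/C=C/C(=O)c2ccccc2-c2cccc(F)c2)cc1OC` gives 160 nM

In a functional assay on SW480 cells (Homo sapiens) for antiproliferative activity, read by sulforhodamine B assay, with a stated time of 48 h (on this read-out higher numbers stand for weaker inhibition and lower numbers for stronger inhibition), compound 2 holds the lower of the two numbers (160 nM). Compound 3 `COc1ccc(/C=C/C(=O)c2ccccc2-c2ccc(F)nc2)cc1OC` is unmeasured and carries 6-fluoropyridin-3-yl in place of 3-fluorophenyl on an aromatic carbon. For the measured compounds named here, the only measured step bearing on this is modest and beyond the scatter (a 3.6-fold lower number from compound 1 to compound 2 (0.55 log units; beyond the scatter)), and it concerns 3-fluorophenyl in place of 4-fluorophenyl. Going by the values given here, no measured step covers a ring nitrogen, so the expectation is loose. A modest step to a higher number is expected (a 2.2-fold higher number from compound 2 to compound 3 (0.34 log units; beyond the scatter)). Compound 3 is estimated at 350 nM (expected range 120 nM to 1000 nM).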

Compound 3, half-maximal inhibitory concentration: 1300 nM
For compound 3 the middle estimate is 3.7-fold (0.57 log units) below the measured one, outside the stated range (above it).
By their numbers in this assay, from the lowest: compound 2; then compound 1; then compound 3.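

In this assay, for the compounds shown here, replacing 3-fluorophenyl with 6-fluoropyridin-3-yl on this aromatic carbon gives the largest step so far, an 8.1-fold higher number from compound 2 to compound 3 (0.91 log units; beyond the scatter). The number also rises relative to the 4-fluorophenyl analogue, a 2.3-fold higher number from compound 1 to compound 3 (0.36 log units; beyond the scatter), so compound 3 has the highest number of the three and this position does not accept every fluoroaryl group equally. No supporting data explain the loss. The separate contributions of the ring nitrogen and the fluorine placement remain unresolved, as does the effect of a chlorophenyl or an unsubstituted pyridinyl group at this position.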